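Swapping the aryl group on the amino nitrogen of compound 2

The source may hold more compounds than are shown below. What is called first, only, known or untested is meant among the compounds shown, and "the series" means these compounds.

The two measured compounds share one core and differ only in the aryl group on the amino nitrogen. Compound 1 `Cc1n[nH]c2ccc(-c3nc4cnc(N5CCN(C)CC5)cn4c3Nc3cccc(F)c3)cc12` gives 18.5% in a functional assay on MV4-11 cells (Homo sapiens) for inhibition, with a stated time of 120 h, tested at 10 uM; on this read-out lower numbers stand for less inhibition and higher numbers for more inhibition at the one concentration tested (going by the name of the read-out). Compound 2 `Cc1n[nH]c2ccc(-c3nc4cnc(N5CCN(C)CC5)cn4c3Nc3ccc(I)cc3)cc12` gives 0% in this assay, the lowest of the two numbers; the step of a number 18.5 percentage points lower from compound 1 to compound 2 (beyond the scatter) separates it from compound 1 and lies beyond the scatter. Compound 3 `Cc1n[nH]c2ccc(-c3nc4cnc(N5CCN(C)CC5)cn4c3Nc3ccc(Cl)cc3F)cc12` has not been measured in this assay. It differs from compound 2 in one place: 4-chloro-2-fluorophenyl in place of 4-iodophenyl on a nitrogen on an aromatic ring. Within the data shown here, the only step that bears on this change is the one from compound 1 to compound 2, in which 4-iodophenyl replaced 3-fluorophenyl and inhibition fell. Compound 3 keeps a halogen at the 4-position of the phenyl and brings back a fluorine, so a small rise, mostly within the scatter, is expected: a number 8 percentage points higher from compound 2 to compound 3 (within the scatter). Compound 3 is therefore estimated at 8%, within 0% to 25%.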

Compound 3, a percentage reported as inhibition, at one concentration (the size of the read-out at that concentration, not a potency): 0%
The estimate for compound 3 lay 8 percentage points above the measured number, and the stated range covers the measured number.
By their numbers in this assay, from the lowest: compounds 2 and 3 (each within the scatter of the next); then compound 1.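

In this assay, putting 4-chloro-2-fluorophenyl in place of 4-iodophenyl on the nitrogen gives no change at the digits printed from compound 2 to compound 3 (within the scatter), so a fluorine on this ring does not by itself bring the reading back. The second new step, a number 18.5 percentage points lower from compound 1 to compound 3 (beyond the scatter), shows that a second aryl group with a halogen at the 4-position also falls short of the 3-fluorophenyl of compound 1, although both groups carry fluorine. Nothing given here explains this difference.

Because compound 2 and compound 3 both read zero at the one concentration tested, the read-out cannot separate them. From the compounds shown here alone, it also remains open how an unsubstituted phenyl, a 3-chlorophenyl or a 3-methoxyphenyl on this nitrogen would compare with the 3-fluorophenyl of compound 1.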